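A few compounds are considered here, and "the series" means these few. Any claim that something is new, unique, unknown or untested is made for them only; others in the source may bear on it.

Measured compounds:
Compound 1, `O=C(NCc1cn(Cc2ccc(Cl)cc2)nn1)c1cn(-c2ccccc2)nc1-c1ccccc1`, in a functional assay on HeLa cells (Homo sapiens) for antiproliferative activity, read by sulforhodamine B assay, with a stated time of 48 h (on this read-out higher numbers stand for weaker inhibition of growth and lower numbers for stronger inhibition of growth), gives 600 nM.
Compound 2, `O=C(NCc1cn(Cc2ccc(Cl)cc2)nn1)c1cn(-c2ccccc2)nc1-c1ccc(F)cc1`, in this assay gives 210 nM.

Among these two numbers compound 2 stands lowest, the nearest being compound 1; the only measured step, a 2.9-fold lower number from compound 1 to compound 2 (0.46 log units; beyond the scatter), lies beyond the scatter and goes to a lower number. Compound 3, `COc1cc(Cn2cc(CNC(=O)c3cn(-c4ccccc4)nc3-c3ccc(F)cc3)nn2)cc(OC)c1`, is not yet measured. It differs from compound 2 by 3,5-dimethoxyphenyl in place of 4-chlorophenyl on a saturated chain carbon bound to an aromatic nitrogen. Going by the values given here, no measured step touches this part of the molecule: the one step in hand concerns fluoro in place of hydrogen elsewhere, and it says nothing about exchanging 4-chlorobenzyl for 3,5-dimethoxybenzyl. The size of this change cannot be anchored in the data, so the step of a 1.9-fold higher number from compound 2 to compound 3 (0.28 log units; within the scatter) is expected to be modest and could fall on either side of compound 2. Compound 3 is therefore estimated at 400 nM in this assay, with a wide range from 100 nM to 1600 nM.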

Compound 3, concentration for 50% growth inhibition: 360 nM
Estimate against measurement, compound 3: 1.1-fold (0.05 log units) above; the range from low to high includes it.
By their numbers in this assay, from the lowest: compounds 2, 3 and 1 (each within the scatter of the next, the first and the last beyond it).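

In this assay, going by these compounds alone, the step of a 1.7-fold higher number from compound 2 to compound 3 (0.23 log units; within the scatter) gives the first reading at this place, on a saturated chain carbon bound to an aromatic nitrogen. It shows that 4-chlorophenyl can be exchanged for 3,5-dimethoxyphenyl, which has more heavy atoms and brings two hydrogen-bond acceptors, without the number moving beyond the scatter. Nothing in the information available accounts for this result.

The compounds shown leave open whether a phenyl ring with a single methoxy group, or one carrying an amine or a carboxylic acid, would read the same at this place. They also leave open whether the same exchange would read alike in compound 1, which has hydrogen where compound 2 has fluoro.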